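This account rests on a few compounds, and the source may have more. Where it says the series, first, only, none or still open, it means among the compounds named here.

Three compounds share one core and differ only in the group on the aromatic ring that sits on the five-membered ring of the fused system. Compound 1 `COc1cc(-c2ccnc3cc(-c4ccc(C)cc4)nn23)cc(OC)c1OC` carries a methyl there, and in a functional assay on HCT-116 cells (Homo sapiens) for inhibition, read by CCK-8 assay, with a stated time of 48 h (on this read-out lower numbers stand for stronger inhibition and higher numbers for weaker inhibition), compound 1 gives 48 nM. Compound 2 `COc1cc(-c2ccnc3cc(-c4ccc(N(C)C)cc4)nn23)cc(OC)c1OC` carries a dimethylamino and gives 2050 nM. Compound 3 `COc1ccc(-c2cc3nccc(-c4cc(OC)c(OC)c(OC)c4)n3n2)cc1` carries a methoxy and gives 404 nM, which places it second highest of the three numbers, closer to compound 2 than to compound 1. The two steps leading to it were an 8.4-fold higher number from compound 1 to compound 3 (0.93 log units; beyond the scatter) and a 5.1-fold lower number from compound 2 to compound 3 (0.71 log units; beyond the scatter), while the step of a 43-fold higher number from compound 1 to compound 2 (1.63 log units; beyond the scatter) was the largest of all.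

Compound 4 `COc1cc(-c2ccnc3cc(-c4ccc(C)c(C)c4)nn23)cc(OC)c1OC` is the next step from compound 3: 3,4-dimethylphenyl in place of 4-methoxyphenyl on an aromatic carbon. For the measured compounds named here, the step that bears most on this is the one from compound 1 to compound 3, which ran in the opposite sense: replacing methyl with methoxy raised the number by a modest amount, so restoring methyl and adding a second one is expected to lower it again. Because compound 1 with its methyl gives 48 nM, compound 4 is expected to land near that level, with the step estimated as a 5.1-fold lower number from compound 3 to compound 4 (0.70 log units; beyond the scatter). For compound 4 the estimate in this assay is 80 nM, with a range from 25 nM to 300 nM.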

Compound 4, half-maximal inhibitory concentration: 261 nM
For compound 4 the middle estimate is 3.3-fold (0.51 log units) below the measured one; measured number inside the range.
By their numbers in this assay, from the lowest: compound 1; then compounds 4 and 3 (each within the scatter of the next); then compound 2.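

In this assay, for the compounds shown here, the only difference between compound 1 and compound 4 is one added methyl that turns the aryl group into 3,4-dimethylphenyl, and that small addition gives a 5.4-fold higher number from compound 1 to compound 4 (0.74 log units; beyond the scatter) beyond the scatter, so this aryl group does not simply tolerate an extra methyl. The earlier compounds shown here only swapped one group for another, whereas this step shows that the number also moves when a group is added to the methyl-bearing ring. At the same time, a 1.5-fold lower number from compound 3 to compound 4 (0.19 log units; within the scatter) means that 3,4-dimethylphenyl, of carbon only, and 4-methoxyphenyl, with its oxygen, cannot be told apart here, while a 7.9-fold lower number from compound 2 to compound 4 (0.90 log units; beyond the scatter) keeps 4-(dimethylamino)phenyl clearly separate from 3,4-dimethylphenyl; nothing supplied here gives a measured reason for any of these differences.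

The compounds shown leave open whether the added methyl would act the same way on a ring without the first one, as in 3-methylphenyl. They also leave open how this position would respond to a chlorine or fluorine atom, an ethyl chain or a hydroxyl group on the same ring.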